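Working notes: from compound 1 to compound 3

This account rests on a few compounds, and the source may have more. Where it says the series, first, only, none or still open, it means among the compounds named here.

Values so far in an ADME assay on HaCaT cells (Homo sapiens) for inhibition, read by sulforhodamine B assay, with a stated time of 48 h; a higher number here means a weaker inhibitor of growth, a lower number a stronger inhibitor of growth:
- compound 1 `Ic1ccc(Cn2cc(CCCOc3cccc4cccnc34)nn2)cc1` gives > 250 ug/mL (a limit, not a number)
- compound 2 `Fc1ccc(Cn2cc(CCCOc3cccc4cccnc34)nn2)cc1` gives 115 ug/mL (a number)

Compound 1 sits at the limit of > 250 ug/mL in this assay, at which 1 of the 2 values shown sits, so it has a limit and no number in this assay as its starting point.

Compound 3 `Clc1cc(Cl)c(Cn2cc(CCCOc3cccc4cccnc34)nn2)c(Cl)c1` carries 2,4,6-trichlorophenyl in place of 4-iodophenyl on a saturated chain carbon bound to an aromatic nitrogen.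

Among the compounds with values here, one measured step bears on this change, since it also removes the iodo group. Fluoro in place of iodo on an aromatic carbon gives an at least 2.1-fold lower number from compound 1 to compound 2 (0.33 log units; beyond the scatter), a step beyond the scatter. That single step involves a different halogen and sets no rule, so the expectation stays loose.

On the strength of that step, a modest move toward a lower number is expected, and the expected step is an at least 1.6-fold lower number from compound 1 to compound 3 (0.22 log units; that floor lies within the scatter) as a working figure. A second limit remains possible. The estimated value for compound 3 is 150 ug/mL, with an expected range from 60 ug/mL to 320 ug/mL as its bounds.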

Compound 3, concentration for 50% growth inhibition: 5.3 ug/mL
For compound 3 the middle estimate is 28-fold (1.45 log units) above the measured one; measured number below the stated range.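

In this assay, the place on a saturated chain carbon bound to an aromatic nitrogen proves far more sensitive than the earlier pair suggested: 2,4,6-trichlorophenyl in place of 4-fluorophenyl gives a 22-fold lower number from compound 2 to compound 3 (1.34 log units; beyond the scatter) and is the firmer reading, with a number at both ends. Going by these compounds, the same group in place of 4-iodophenyl gives an at least 47-fold lower number from compound 1 to compound 3 (1.67 log units; beyond the scatter) but starts from a limit and not a number, so its full size stays unknown because of how compound 1 reads: the limit of > 250 ug/mL in this assay, at which 1 of the 3 values shown sits. The exchange of one halogen for another in the earlier step, an at least 2.1-fold lower number from compound 1 to compound 2 (0.33 log units; beyond the scatter) in this series, gave no sign of a move of this size, so the group at this place can shift the read-out by much more than that step implied.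

On these data alone, whether the large step belongs to chlorine itself, to the number of chlorines or to their placement on the ring stays open. Also open, as far as these compounds go, is where a phenyl carrying a single chloro, an unsubstituted phenyl, or a phenyl carrying a methoxy or a carboxylic acid would fall.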